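This account rests on a few compounds, and the source may have more. Where it says the series, first, only, none or still open, it means among the compounds named here.

Measured in an assay on HEK293 cells for agonist activity at transient receptor potential cation channel subfamily M member 8 (Homo sapiens), read by fluorescence and calcium flux, with a stated time of 15 min; on this read-out higher numbers stand for an effect only at larger amounts of compound and lower numbers for an effect already at smaller amounts:
compound 1 `Cc1ccc(OCC(=O)N(Cc2cccs2)c2cnn(C)c2)cc1` gives 63000 nM
compound 2 `Cc1ccc(OCC(=O)N(CCCO)Cc2cccs2)cc1` gives 3000 nM
compound 3 `Cc1ccc(OCC(=O)N(Cc2cccs2)c2nccs2)cc1` gives 2240 nM

Compound 3 shows the lowest number of the three, yet the gap to compound 2, a 1.3-fold lower number from compound 2 to compound 3 (0.13 log units; within the scatter), stays within the scatter; only compound 1 sits clearly apart, as a 28-fold lower number from compound 1 to compound 3 (1.45 log units; beyond the scatter) and a 21-fold lower number from compound 1 to compound 2 (1.32 log units; beyond the scatter) show.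

Compound 4 `COCCN(Cc1cccs1)C(=O)COc1ccc(C)cc1` differs from compound 3 in one place: 2-methoxyethyl in place of 1,3-thiazol-2-yl on an amide-type nitrogen. The step that bears on this is a 1.3-fold lower number from compound 2 to compound 3 (0.13 log units; within the scatter), where a 3-hydroxypropyl chain and the same 1,3-thiazol-2-yl ring gave numbers within the scatter of each other. A short open chain on the amide-type nitrogen therefore seems tolerated in this assay, and for compound 4 no step beyond the scatter is expected, a 1.3-fold higher number from compound 3 to compound 4 (0.10 log units; within the scatter). Compound 4 is estimated at 2800 nM, with a range of 1000 nM to 8000 nM.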

Compound 4, half-maximal effective concentration: 400 nM
Compound 4: middle estimate off by 7.0-fold (0.85 log units), on the high side; measured number below the stated range.
By their numbers in this assay, from the lowest: compound 4; then compounds 3 and 2 (each within the scatter of the next); then compound 1.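

In this assay an open chain on the amide-type nitrogen does more than match a ring: 2-methoxyethyl gives lower numbers than 1,3-thiazol-2-yl (a 5.6-fold lower number from compound 3 to compound 4 (0.75 log units; beyond the scatter)) and 1-methyl-1H-pyrazol-4-yl (a 160-fold lower number from compound 1 to compound 4 (2.20 log units; beyond the scatter)). The two open chains also separate beyond the scatter, with methoxy in place of hydroxymethyl on a saturated chain carbon (a 7.5-fold lower number from compound 2 to compound 4 (0.88 log units; beyond the scatter)), so this position responds to the chain end as well as to the presence of a chain. Nothing at hand explains these steps. Open, going by these compounds, is whether a longer chain ending in methoxy keeps the low number, and how a chain ending in an amine or a carboxylic acid compares at this nitrogen.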